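A few compounds are considered here, and "the series" means these few. Any claim that something is new, unique, unknown or untested is made for them only; others in the source may bear on it.

Measured so far in a functional assay on MCF7 cells (Homo sapiens) for cytotoxicity, read by MTT assay, with a stated time of 72 h; on this read-out lower numbers stand for stronger inhibition and higher numbers for weaker inhibition:
Compound 1 `O=C(Nc1ccccc1)Nc1ccc(C(=O)NO)cc1`: > 50000 nM (a limit)
Compound 2 `O=C(Nc1ccc(Cl)cc1)Nc1ccc(C(=O)NO)cc1`: > 50000 nM (a limit)

Compound 1 has no exact number on this read-out: compound 1 gives > 50000 nM, which is a limit. The next compound to follow is compound 3 `O=C(/C=C/c1ccc(NC(=O)Nc2ccccc2)cc1)NO`, which differs from compound 1 in one group: 2-(hydroxycarbamoyl)ethenyl in place of hydroxycarbamoyl on an aromatic carbon. In words, 2-(hydroxycarbamoyl)ethenyl takes the place of hydroxycarbamoyl on an aromatic carbon.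

The measured data offer little guidance. For the measured compounds named here, the only measured step is a step that the two limits leave unreadable from compound 1 to compound 2, and it involves a different change, chloro in place of hydrogen on an aromatic carbon. Both compounds give the same kind of result, (the limit of > 50000 nM in this assay, at which 2 of the 2 values shown sit), so neither the size nor the direction of any effect can be read from them. Any expectation for compound 3 is therefore a cautious one: a modest gain in this assay at best, and a result reported only as a limit would be no surprise. The expected change is an at least 2.5-fold lower number from compound 1 to compound 3 (0.39 log units; beyond the scatter). For compound 3 the estimated value is 20000 nM, with an expected range from 4000 nM to 60000 nM.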

Compound 3, half-maximal inhibitory concentration: > 50000 nM
Compound 3: only a limit was reported (the forecaster's own chance of this, stated with the estimate: 40%); at least 2.5-fold (0.39 log units) between middle value and limit.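

For the compounds shown here, compound 3, like compound 1, is reported in this assay only as a limit, not an exact number, so no step from compound 1 to compound 3 can be read: the limit of > 50000 nM in this assay, at which 3 of the 3 values shown sit. The compounds shown leave open what exact value each would give, and whether either chloro or 2-(hydroxycarbamoyl)ethenyl changes that value in any direction.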